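Compound 1 and a change at the carbonyl carbon

The source may report more compounds than this note shows. Statements on the series, on what has been measured and on what is new or still open speak of the compounds shown alone.

Among the measured compounds shown here, compound 1 `COc1cc(-c2nn(-c3cccc(NC(=O)Nc4ccc(Cl)c(Cl)c4)c3)cc2-c2ccncc2)ccc1Cl` and compound 2 `O=C(Nc1cccc(-n2cc(-c3ccncc3)c(-c3ccc(Cl)c(O)c3)n2)c1)Nc1ccc(Cl)c(Cl)c1` are the two compounds measured so far. In a functional assay on SR cells (Homo sapiens) for inhibition, read by sulforhodamine B assay, with a stated time of 48 h (a lower number here means a stronger inhibitor of growth, a higher number a weaker inhibitor of growth), compound 1 gives 932 nM, and compound 2 gives 1140 nM. For the measured compounds named here, compound 1 therefore holds the lower of the two numbers, though the only measured step, a 1.2-fold higher number from compound 1 to compound 2 (0.09 log units; within the scatter), a hydrogen in place of a methyl on an oxygen on an aromatic ring, is within the scatter, so the two cannot be told apart.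

Compound 3 `COc1cc(-c2nn(-c3cccc(NC(=O)c4ccc(Cl)c(C(F)(F)F)c4)c3)cc2-c2ccncc2)ccc1Cl` has not yet been measured. It differs from compound 1 at the carbonyl carbon: 4-chloro-3-(trifluoromethyl)phenyl in place of (3,4-dichlorophenyl)amino on a carbonyl carbon. Going by the values given here, no measured step touches this part of the shared core; the one step recorded concerns the oxygen substituent on another ring. There is thus nothing to anchor a direction, and the expectation for this assay is that compound 3 will stay close to compound 1, with no step beyond the scatter, a 1.3-fold higher number from compound 1 to compound 3 (0.11 log units; within the scatter). Compound 3 is estimated at 1200 nM, with a range from 400 nM to 4000 nM.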

Compound 3, concentration for 50% growth inhibition: 848 nM
For compound 3 the middle estimate is 1.4-fold (0.15 log units) above the measured one; the range from low to high includes it.
By their numbers in this assay, from the lowest: compounds 3, 1 and 2 (each within the scatter of the next).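

In this assay, among the compounds shown here, the first change at the carbonyl carbon comes out as a 1.1-fold lower number from compound 1 to compound 3 (0.04 log units; within the scatter), so 4-chloro-3-(trifluoromethyl)phenyl and (3,4-dichlorophenyl)amino cannot be told apart here. The earlier pair spoke only to the oxygen substituent on another ring, whereas this pair shows that the group on the carbonyl carbon can be exchanged without a step beyond the scatter, even though the hydrogen-bond donor of the leaving group is absent from the entering group and the entering group has more heavy atoms. Nothing available explains why the two groups read alike, and no outside measurement bears on it.

Both groups carry a chlorinated six-membered aromatic ring of carbon only, so the compounds shown leave open whether a group without such a ring, such as cyclohexyl or morpholine, or one bearing a carboxylic acid, would give a number outside the scatter of compound 1 in this assay. They also leave open whether the 4-chloro-3-(trifluoromethyl)phenyl group would read the same on the core of compound 2, which carries the hydroxyl in place of the methoxy group.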